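EP3 antagonist series: aminotriazole replaced by cyanoimino-imidazolidine

This account rests on a few compounds, and the source may have more. Where it says the series, first, only, none or still open, it means among the compounds named here.

Measured so far:
compound 1 `CC(C)C(Nc1nnc[nH]1)c1ccc(-c2ccc3cccc(F)c3c2)[nH]c1=O` — 185 nM
compound 2 `CCn1ncc2c(F)cc(-c3ccc(C(CC)(CC)c4nnc(C)[nH]4)c(=O)[nH]3)cc21` — 90 nM

Both numbers come from a functional assay on CHO cells for antagonist activity at prostaglandin E2 receptor EP3 subtype (Homo sapiens), read by cAMP accumulation; on this read-out higher numbers stand for weaker inhibition and lower numbers for stronger inhibition. Compound 1 has the highest of the two values; compound 2, with a different core and a different heteroaryl arm, gives the lower number, and that gap lies beyond the scatter. For the measured compounds named here, no pair of compounds differing in one place has been measured, so no single step has a known size.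

Compound 3 `CC(C)C(c1ccc(-c2ccc3cccc(F)c3c2)[nH]c1=O)N1CCN/C1=N\C#N` is the next candidate. It differs from compound 1 in one place: a group of 8 heavy atoms (4 carbon, 4 nitrogen; one five-membered non-aromatic ring with 2 hetero atoms) in place of a group of 6 heavy atoms (2 carbon, 4 nitrogen; one five-membered aromatic ring with 3 hetero atoms), on a saturated chain carbon bound to an aromatic carbon and a saturated chain carbon. Going by the values given here, the aminotriazole of compound 1 carries the only direct precedent, and nothing measured shows how its replacement shifts the read-out in this assay. The step from compound 1 to compound 3 is therefore expected to be modest, most likely toward a somewhat higher number, with wide uncertainty in both directions, as a 1.6-fold higher number from compound 1 to compound 3 (0.21 log units; within the scatter) expresses. Compound 3 is accordingly estimated at 300 nM, within 80 nM to 1200 nM.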

Compound 3, half-maximal inhibitory concentration: 38 nM
For compound 3 the middle estimate is 7.9-fold (0.90 log units) above the measured one; measured number outside the range, below it.
By their numbers in this assay, from the lowest: compound 3; then compound 2; then compound 1.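

In this assay, a group on the saturated chain carbon bound to an aromatic carbon and a saturated chain carbon can change without loss: replacing the (4H-1,2,4-triazol-3-yl)amino group with the cyanoimino-imidazolidine gives a 4.9-fold lower number from compound 1 to compound 3 (0.69 log units; beyond the scatter). For the compounds shown here, this is the first single change of known size, and it shows that an aromatic five-membered ring is not required at this place, nor are the 2 hydrogen-bond donors and 3 hydrogen-bond acceptors of the group that leaves. Nothing available accounts for the size of this step.

Going by these compounds, whether the step carries over to the core of compound 2 remains open. Also open, on these data alone, is which part of the entering group carries it; a urea carbonyl in place of the cyanoimino group, or a piperazine-sized six-membered ring, would test this.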